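Hetero ring out, cyclopropyl in: permeability expectation

The compounds below may be only part of what the source reports. "The series", "measured", "known", "first", "only" and "open" are said of these compounds alone.

For the measured compounds named here, compound 2 `CCCCc1nc(=O)c(S(=O)(=O)c2ccc(-n3ccccc3=O)cc2)c(O)n1-c1c(OC)cccc1OC` gives 1 nm/s in an ADME assay for permeability, using PAMPA, at pH 7.4 (on this read-out lower numbers stand for lower permeability and higher numbers for higher permeability), and stands lowest of the two numbers measured so far. Compound 1 `CCCCc1nc(=O)c(S(=O)(=O)c2ccc(-c3ccc(F)cc3)cc2)c(O)n1-c1c(OC)cccc1OC` gives 132 nm/s in this assay. These two differ in one place, joined by the step of a 130-fold lower number from compound 1 to compound 2 (2.12 log units; beyond the scatter). Compound 3 `CCCCc1nc(=O)c(S(=O)(=O)c2ccc(C3CC3)cc2)c(O)n1-c1c(OC)cccc1OC` has not yet been measured. It differs from compound 2 by a group of 3 heavy atoms (3 carbon; one three-membered non-aromatic ring of carbon only) in place of a group of 7 heavy atoms (5 carbon, 1 nitrogen, 1 oxygen; one six-membered aromatic ring with 1 hetero atom), on an aromatic carbon. Going by the values given here, the only measured step that bears on this change is a 130-fold lower number from compound 1 to compound 2 (2.12 log units; beyond the scatter), where the six-membered aromatic ring with 1 hetero atom entered in place of a six-membered aromatic ring of carbon only and the number fell far beyond the scatter. Here that hetero ring leaves again and cyclopropyl enters, so a large rise is expected, though the entering group is not the one seen in compound 1. Compound 3 is expected to give 100 nm/s, within 30 nm/s to 300 nm/s. The expected step is a 100-fold higher number from compound 2 to compound 3 (2.00 log units; beyond the scatter).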

Compound 3, apparent permeability: 22 nm/s
For compound 3 the middle estimate is 4.5-fold (0.66 log units) above the measured one; the whole stated range lies above it.
By their numbers in this assay, from the lowest: compound 2; then compound 3; then compound 1.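

Taking out the hetero ring gives a 22-fold higher number from compound 2 to compound 3 (1.34 log units; beyond the scatter) in this assay, so the very low number does not come from the shared core alone. The recovery is only partial, though: swapping 4-fluorophenyl for cyclopropyl gives a 6.0-fold lower number from compound 1 to compound 3 (0.78 log units; beyond the scatter), so these two carbon-only groups are not interchangeable at this position. Three groups on the same aromatic carbon now give three clearly separated numbers, which shows that the read-out depends on which group sits there and not just on whether the hetero ring is absent.

On these data alone, how plain phenyl, a longer chain such as butyl, or an amine would rank on this same carbon remains open. Nothing here gives a reason for these differences.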